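Cyanoguanidines on the pyridine core: a ring enters

The source may report more compounds than this note shows. Statements on the series, on what has been measured and on what is new or still open speak of the compounds shown alone.

Measured so far:
compound 1, `CCCC/N=C(\NC#N)Nc1cccnc1`, 20 mg/kg
compound 2, `CC(C)(C)C/N=C(/NC#N)Nc1cccnc1`, 2.5 mg/kg

The two measured compounds share a core and differ only in the group on the double-bonded nitrogen. In a functional assay on the whole organism (blood, strain Wistar-Okamoto) with Rattus norvegicus as the target, with a stated time of 5 days (a higher number here means that more compound is needed for the effect, a lower number that less compound is needed), compound 1 gives 20 mg/kg, the highest of the two numbers. Compound 2 stands nearest, and in this assay compound 2 gives 2.5 mg/kg, a gap that lies beyond the scatter, so compound 2 needs less compound for the effect.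

Compound 3, `CC1(/N=C(\NC#N)Nc2cccnc2)CCC1`, has not yet been measured in this assay. It differs from compound 1 in one place: 1-methylcyclobutyl in place of butyl on a double-bonded nitrogen. For the measured compounds named here, the structural change brings a ring into this position; no measured pair in this set tells how such a ring is tolerated.

Going by the values given here, a step in the same direction as the gap between compound 1 and compound 2 is expected, estimated as a 3.3-fold lower number from compound 1 to compound 3 (0.52 log units; beyond the scatter), of moderate size rather than large, since the only guide is that compound 2 gives 2.5 mg/kg with another group at the same position. Compound 3 is therefore expected to give about 6 mg/kg in this assay, within a range from 2 mg/kg to 20 mg/kg.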

Compound 3, minimum effective dose: 50 mg/kg
Compound 3: the middle estimate sits 8.3-fold (0.92 log units) below what was measured; the whole stated range lies below it.
By their numbers in this assay, from the lowest: compound 2; then compound 1; then compound 3.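

In this assay the change to 1-methylcyclobutyl in place of butyl on the double-bonded nitrogen gives a 2.5-fold higher number from compound 1 to compound 3 (0.40 log units; beyond the scatter) and so shows that this position does not reward every bulkier carbon group, although the step is modest and the counts of hydrogen-bond donors, hydrogen-bond acceptors and net charge stay the same. The position therefore separates closely sized groups of carbon only, since compound 2 gives 2.5 mg/kg while compound 3 gives 50 mg/kg and now stands with the highest number of the three. The data at hand offer no measurement that accounts for the higher number with this ring.

The compounds shown leave open whether the effect belongs to the four-membered ring itself or to the carbon bearing the methyl group, which a cyclopropyl, a cyclopentyl or a cyclohexyl group, or an open tert-butyl group, at the same nitrogen could help to separate. They also leave open how a ring holding an ether oxygen or an amine would fare at this position.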